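Fluoro to Methyl Swap Tested on a Second Core

A few compounds are considered here, and "the series" means these few. Any claim that something is new, unique, unknown or untested is made for them only; others in the source may bear on it.

Compound 2 `Cc1nc(-c2ccccc2)sc1COc1ccc(OCC(=O)O)c(F)c1` carries a fluoro group on a shared core; in an assay on CHO cells for agonist activity at Free fatty acid receptor 1 (Homo sapiens), read by FLIPR (on this read-out higher numbers stand for an effect only at larger amounts of compound and lower numbers for an effect already at smaller amounts), compound 2 gives 374 nM. Compound 1 `Cc1cc(OCc2sc(-c3ccccc3)nc2C)ccc1OCC(=O)O` differs from it by methyl in place of fluoro on an aromatic carbon. In this assay compound 1 gives > 10000 nM, which is a limit of the assay rather than a number. The step is an at least 26-fold higher number from compound 2 to compound 1 (1.42 log units; beyond the scatter). Compound 3 `O=C(O)COc1ccc(OCc2nnc(-c3ccccc3)s2)cc1F` keeps the fluoro group but sits on a different core; the difference between the core of compound 2 and the core of compound 3 is not broken down here. In this assay compound 3 gives > 10000 nM, which is also a limit. Compound 4 `Cc1cc(OCc2nnc(-c3ccccc3)s2)ccc1OCC(=O)O`, not yet measured, differs from compound 3 by methyl in place of fluoro on an aromatic carbon; the surroundings of the place are described in the same words, so this is the same change as from compound 2 to compound 1. Compound 3 already sits at the limit of > 10000 nM in this assay, at which 2 of the 3 values shown sit, and the earlier step of an at least 26-fold higher number from compound 2 to compound 1 (1.42 log units; beyond the scatter) pushed the number higher. Compound 4 is therefore expected to stay at that limit, with an expected step that the limit leaves unreadable from compound 3 to compound 4. Compound 4 is estimated at 40000 nM, between 10000 nM and 150000 nM.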

Compound 4, half-maximal effective concentration: > 10000 nM
Compound 4: no number, only a limit (the forecaster's own chance of this, stated with the estimate: 90%); the middle value is on the limit's open side.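

In this assay compound 4 gives > 10000 nM, which is a limit and not a number. Compound 3 also sits at a limit, so no step can be read from compound 3 to compound 4: the limit of > 10000 nM in this assay, at which 3 of the 4 values shown sit.

The compounds shown leave open whether methyl in place of fluoro changes the read-out at all on the core of compound 3.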